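Aryl variation on the shared core: thiophene in place of chlorophenyl

The source may hold more compounds than are shown below. What is called first, only, known or untested is meant among the compounds shown, and "the series" means these compounds.

Measured in an assay on HEK293 cells for displacement of a labelled ligand from 5-hydroxytryptamine receptor 6 (Homo sapiens); on this read-out lower numbers stand for stronger inhibition and higher numbers for weaker inhibition:
compound 1 `CN1CCN(c2nc(N)nc(Cc3cccc(Cl)c3)n2)CC1`: 28 nM
compound 2 `CN1CCN(c2nc(N)nc(Cc3cccc(F)c3)n2)CC1`: 64 nM
compound 3 `CN1CCN(c2nc(N)nc(Cc3ccc(F)cc3)n2)CC1`: 100 nM

Compound 1 gives the lowest number of the three; a 2.3-fold higher number from compound 1 to compound 2 (0.36 log units; beyond the scatter) and a 3.6-fold higher number from compound 1 to compound 3 (0.55 log units; beyond the scatter), both beyond the scatter, so compound 1 is the strongest binder among the measured set. Between the other two, a 1.6-fold higher number from compound 2 to compound 3 (0.19 log units; within the scatter), which is within the scatter.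

Compound 4 `CN1CCN(c2nc(N)nc(Cc3cccs3)n2)CC1` has not been measured. Relative to compound 1 the change is thiophen-2-yl in place of 3-chlorophenyl on a saturated chain carbon bound to an aromatic carbon. Among the compounds with values here, the steps that bear on it are those that touch the same group: fluoro in place of chloro weakens binding moderately, and the move to 4-fluorophenyl weakens it somewhat more. Within the data shown here, both steps indicate that compound 1 owes part of its binding to the chloro, which compound 4 loses entirely; no measured step covers the exchange of a six-membered ring for a five-membered one, so that part of the change is untested. A modest weakening is therefore expected for compound 4, about a 2.9-fold higher number from compound 1 to compound 4 (0.46 log units; beyond the scatter). The estimate for compound 4 in this assay is 80 nM, with a range from 30 nM to 220 nM.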

Compound 4, inhibition constant: 305 nM
For compound 4 the middle estimate is 3.8-fold (0.58 log units) below the measured one; measured number above the stated range.
By their numbers in this assay, from the lowest: compound 1; then compounds 2 and 3 (each within the scatter of the next); then compound 4.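

In this assay, thiophen-2-yl in place of 3-chlorophenyl on the saturated chain carbon gives an 11-fold higher number from compound 1 to compound 4 (1.04 log units; beyond the scatter) and is a large step, whereas the halogen changes among the phenyl compounds were modest. Loss of the chloro alone does not account for this result, as compound 4 also falls short of both fluorophenyl compounds, with a 4.8-fold higher number from compound 2 to compound 4 (0.68 log units; beyond the scatter) and a 3.1-fold higher number from compound 3 to compound 4 (0.48 log units; beyond the scatter) all beyond the scatter. This position therefore responds to the identity of the ring as well as to its halogen, and compound 4 is the weakest binder of the four, but no available data explain the drop.

The compounds shown do not separate the effect of the ring change from that of removing the halogen, a question that plain phenyl and a chloro-substituted thiophene would address directly. Also open, on these data alone, is how this position responds to a six-membered ring containing nitrogen, such as pyridyl, or to a phenyl ring carrying methoxy or an amine.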